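Compound 4: Adding Butyl Beyond an Assay Limit

The compounds below may be only part of what the source reports. "The series", "measured", "known", "first", "only" and "open" are said of these compounds alone.

Three compounds sharing one core differ in the length of one chain. In a functional assay on brain (Rattus norvegicus, strain Wistar) for inhibition (on this read-out lower numbers stand for stronger inhibition and higher numbers for weaker inhibition), compound 1 `CCCCCCc1ccc(-c2c(C)[nH]c(=O)n2C2CCCCC2)cc1` gives 13700 nM and compound 2 `CCCCCCCCCCc1ccc(-c2c(C)[nH]c(=O)n2C2CCCCC2)cc1` gives 27000 nM. Compound 3 `CCCCCCCCCCCCCCc1ccc(-c2c(C)[nH]c(=O)n2C2CCCCC2)cc1` reaches only a limit of the assay, > 100000 nM. It is the weakest of the three. Compound 4 `CCCCCCCCCCCCCCCCCCc1ccc(-c2c(C)[nH]c(=O)n2C2CCCCC2)cc1` carries one further change: butyl in place of hydrogen on a saturated chain carbon, ten or more bonds along the chain from an aromatic carbon. Two measured steps made the same change lower on the chain: a 2.0-fold higher number from compound 1 to compound 2 (0.29 log units; within the scatter), and an at least 3.7-fold higher number from compound 2 to compound 3 (0.56 log units; beyond the scatter). Neither points toward stronger inhibition, so a modest move toward weaker inhibition is expected. The expected step is a step that the limit leaves unreadable from compound 3 to compound 4. Compound 4 is estimated at 200000 nM, with an expected range from 100000 nM to 600000 nM.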

Compound 4, half-maximal inhibitory concentration: > 100000 nM
Compound 4: no number, only a limit; the forecaster's own chance of this, stated with the estimate: 90%; the middle value is on the limit's open side.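

In this assay compound 4 gives > 100000 nM, a limit of the assay and not a number. Compound 3 also stands at a limit, so the step between these two compounds cannot be read, and the added butyl shows no measurable effect at this position. Against the shorter chains the change can still be read, as an at least 3.7-fold higher number from compound 2 to compound 4 (0.56 log units; beyond the scatter) and an at least 7.2-fold higher number from compound 1 to compound 4 (0.86 log units; beyond the scatter). The compounds shown leave open how much weaker inhibition becomes past the limit. They also leave open whether a shorter chain, or an amine on the chain, would give a lower number.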